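Removing the 3-chlorobenzyl group from compound 3

The compounds below may be only part of what the source reports. "The series", "measured", "known", "first", "only" and "open" are said of these compounds alone.

Of the compounds shown here, three have been measured in an assay on CHO cells for displacement of a labelled ligand from adenosine receptor A3 (Homo sapiens), tested at 10 uM; on this read-out lower numbers stand for less inhibition and higher numbers for more inhibition at the one concentration tested (going by the name of the read-out). Compound 1 `Nc1ncnc2c1ncn2[C@H]1C[C@@H](CO)CO1` gives 31% in this assay, compound 2 `CCNC(=O)[C@@H]1CO[C@@H](n2cnc3c(N)ncnc32)[C@@H]1O` gives 10%, and compound 3 `OC[C@@]1(O)CO[C@@H](n2cnc3c(NCc4cccc(Cl)c4)ncnc32)[C@@H]1O` gives 43%. Compound 3 therefore stands highest of the three; its nearest neighbour is compound 1, whose number is lower by a margin beyond the scatter, and compound 2 lies further below it, again beyond the scatter. Compound 1 and compound 2 both carry a plain amino group on the shared core, while compound 3 alone carries the (3-chlorobenzyl)amino group.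

Compound 4 `Nc1ncnc2c1ncn2[C@@H]1OC[C@](O)(CO)[C@H]1O` has not yet been measured in this assay. It differs from compound 3 in one place: hydrogen in place of 3-chlorobenzyl on a nitrogen on an aromatic ring. Among the measured compounds shown here, no step between measured compounds covers exactly this change, so its size has to be judged from what compound 1 and compound 2 show with their amino group compared to compound 3. On that basis the step of a number 23 percentage points lower from compound 3 to compound 4 (beyond the scatter) is expected to be downward and beyond the scatter. Compound 4 is estimated to give 20% in this assay, with a likely range from 5% to 38%.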

Compound 4, a percentage reported as inhibition, at one concentration (the size of the read-out at that concentration, not a potency): 35%
Compound 4: middle estimate off by 15 percentage points, on the low side, within the range that was stated.
By their numbers in this assay, from the lowest: compound 2; then compounds 1, 4 and 3 (each within the scatter of the next, the first and the last beyond it).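

In this assay, among the compounds shown here, the step of a number 8 percentage points lower from compound 3 to compound 4 (within the scatter) gives the first direct reading of this change, and it shows that replacing 3-chlorobenzyl with hydrogen on a nitrogen on an aromatic ring does not separate the pair beyond the scatter. For the compounds shown here, although the change removes the whole six-membered aromatic ring of carbon only, this pair therefore gives no sign that the 3-chlorobenzyl group is needed for the inhibition seen at the one concentration tested, something the earlier compounds, which differ in more than one place, could not show. No measurement given here accounts for this result.

The compounds shown leave open whether a plain benzyl group without the chlorine, a methyl group or a longer chain such as phenylethyl on this nitrogen would give a step beyond the scatter. They also leave open whether the same exchange of (3-chlorobenzyl)amino for amino would give a similar step on the core of compound 1 or compound 2, and how the pair would compare across a range of concentrations.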